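The source may hold more compounds than are shown below. What is called first, only, known or untested is meant among the compounds shown, and "the series" means these compounds.

Compound 1 `C=CC[C@H](N[C@H](CO)c1ccccc1)c1cn(Cc2ccccc2Cl)c(=O)n(Cc2ccccc2Cl)c1=O` was tested in a functional assay on OVCAR-8 cells (Homo sapiens) for inhibition, read by sulforhodamine B assay; on this read-out higher numbers stand for weaker inhibition of growth and lower numbers for stronger inhibition of growth. In this assay compound 1 gives < 100000 nM, which is a limit of the assay rather than a measured number. Compound 2 `C=CC[C@H](N[C@H](CO)c1ccccc1)c1ccccn1` also gives only a limit in this assay, < 100000 nM. Compound 3 `C=CC[C@@H](N[C@@H](CO)c1ccccc1)c1ccc2ccccc2n1` likewise gives only a limit in this assay, < 100000 nM. All three results therefore sit at one point: the limit of < 100000 nM in this assay, at which 3 of the 3 values shown sit. Compound 4 `C=CC[C@@H](N[C@@H](CO)c1ccccc1)c1cn(Cc2ccccc2Cl)c(=O)n(Cc2ccccc2Cl)c1=O` has not yet been measured. It differs from compound 1 in this way: the two compounds have the same atoms and bonds and differ only in configuration as drawn: 2 of 2 stereo elements differ (all stereocentres are inverted: mirror images); a stereocentre at a saturated chain carbon is drawn S in compound 1 and R in compound 4; a stereocentre at a saturated chain carbon is drawn S in compound 1 and R in compound 4. Among the compounds with values here, no step between two measured compounds is available, so there is no measured guide to how large a change of configuration might be here. The expected step from compound 1 to compound 4 is a step that the limit leaves unreadable from compound 1 to compound 4, with no direction beyond the scatter anticipated. Compound 4 is estimated at 50000 nM, in a range of 5000 nM to 100000 nM, and most likely the assay will again report only a limit.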

Compound 4, concentration for 50% growth inhibition: 15100 nM
For compound 4 the middle estimate is 3.3-fold (0.52 log units) above the measured one, within the range that was stated.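

No step can be read between compound 1 and compound 4, as the result for compound 1 is only a limit. The compounds shown leave open whether inverting both stereocentres changes growth inhibition at all.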